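Series notes: dimethylamino added to the phenoxy ring of compound 1

The source may report more compounds than this note shows. Statements on the series, on what has been measured and on what is new or still open speak of the compounds shown alone.

In a physicochemical assay for acid dissociation, compound 1 `COc1cccc(CNCCCNc2ccnc3cc(Oc4ccccc4)ccc23)c1O` gives 9.28, level with compound 2 `c1ccc(Oc2ccc3c(NCCCNCc4ccco4)ccnc3c2)cc1` at 9.28; together these are the lowest of three numbers, and compound 3 `FC(F)(F)c1cc(-c2ccc3c(NCCCNCc4ccco4)ccnc3c2)cc(C(F)(F)F)c1` at 9.47 lies within the scatter of both. For the measured compounds named here, the single measured step, no change at the digits printed from compound 1 to compound 2 (within the scatter), leaves the number unchanged. Compound 4 `COc1cccc(CNCCCNc2ccnc3cc(Oc4cccc(N(C)C)c4)ccc23)c1O` differs from compound 1 by dimethylamino in place of hydrogen on an aromatic carbon. Going by the values given here, no measured step alters the phenoxy part of the shared core; where compound 2 reads 9.28 and compound 3 reads 9.47, the two are within the scatter of each other. The expected step of a number 0.02 log units higher from compound 1 to compound 4 (within the scatter) is therefore none beyond the scatter. Compound 4 is estimated at 9.3, with a range of 9 to 9.6.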

Compound 4, acid dissociation constant: 9.28
Estimate against measurement, compound 4: 0.02 log units above, within the range that was stated.
By their numbers in this assay, from the lowest: compounds 1, 2, 4 and 3 (each within the scatter of the next).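

In this assay the phenoxy ring of the shared core now carries a measured change: dimethylamino in place of hydrogen on an aromatic carbon, meta to a large group, gives no change at the digits printed from compound 1 to compound 4 (within the scatter). For the compounds shown here, the earlier compounds held no step at this position, so this is the first reading of phenoxy to 3-(dimethylamino)phenoxy. Nothing available bears on the cause of this result. As far as these compounds go, whether a carboxylic acid or a primary amine at the same place reads alike stays open. So does dimethylamino on the phenoxy ring of compound 2.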